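Replacing the Propylcarbonyl on Compound 2 with Methoxy

The source may report more compounds than this note shows. Statements on the series, on what has been measured and on what is new or still open speak of the compounds shown alone.

Measured so far in a functional assay on the whole organism with Mus musculus as the target, in the hot plate test; on this read-out higher numbers stand for an effect only at larger amounts of compound and lower numbers for an effect already at smaller amounts:
- compound 1 `Clc1ccc2[nH]cc(SC3CCNCC3)c2c1` gives 1.2 mg/kg
- compound 2 `CCCC(=O)N1CCC(Sc2c[nH]c3ccc(Cl)cc23)CC1` gives 22.7 mg/kg
- compound 3 `CN1CCC(Sc2cn(C)c3ccc(Br)cc23)CC1` gives 8.6 mg/kg

All three compounds share the same core and differ only in what sits on the ring nitrogen and, for compound 3, in the groups on the aromatic part. Compound 2 stands at the highest number of the three: compound 3 lies lower, and compound 1 lies lowest, both gaps beyond the scatter.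

Compound 4 `CON1CCC(Sc2c[nH]c3ccc(Cl)cc23)CC1` is not yet measured. It differs from compound 2 in one place: methoxy in place of propylcarbonyl on an amine nitrogen in a ring. Among the compounds with values here, the one measured step that bears on this position is a 19-fold higher number from compound 1 to compound 2 (1.28 log units; beyond the scatter), where placing the propylcarbonyl on the ring nitrogen moved the number far upward from the bare hydrogen. Within the data shown here, compound 4 removes that propylcarbonyl again but does not return to hydrogen; it carries a smaller group in the same place, and no measured pair shows what a methoxy does there. The expectation is therefore a downward step from compound 2 to compound 4, a 5.0-fold lower number from compound 2 to compound 4 (0.70 log units; beyond the scatter), smaller than a full return to compound 1 but beyond the scatter. Compound 4 is expected to give about 4.5 mg/kg in this assay, between 1.5 mg/kg and 13 mg/kg.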

Compound 4, dose for half-maximal effect: 2.3 mg/kg
Beside the measured number, compound 4's estimate is 2.0-fold (0.29 log units) above it, and the stated range covers the measured number.
By their numbers in this assay, from the lowest: compounds 1 and 4 (each within the scatter of the next); then compound 3; then compound 2.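

In this assay the exchange of propylcarbonyl for methoxy on the amine nitrogen in the ring gives a 9.9-fold lower number from compound 2 to compound 4 (0.99 log units; beyond the scatter) and so shows that the large rise seen with a 19-fold higher number from compound 1 to compound 2 (1.28 log units; beyond the scatter) does not come with every group placed on this nitrogen. Measured against the plain hydrogen, methoxy gives a 1.9-fold higher number from compound 1 to compound 4 (0.28 log units; within the scatter) and this step lies within the scatter, so this read-out cannot separate the two compounds and the ring nitrogen can carry at least this one small group without a measurable loss. Nothing measured here explains why propylcarbonyl and methoxy behave so differently at this position.

Going by these compounds, it remains open which feature of propylcarbonyl goes with the higher number, its carbonyl or its chain, since these two groups differ in both at once; a shorter acetyl group or a plain butyl chain on the same nitrogen would bear on that question. Also open, on these data alone, is whether a longer ether such as propoxy would stay with compound 4 or move towards compound 2.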